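Amide aryl replacement in the cell toxicity screen

This account rests on a few compounds, and the source may have more. Where it says the series, first, only, none or still open, it means among the compounds named here.

Measured so far:
compound 1 `COc1ccc(NC(=O)COc2cc(C)nc3ccc(OC)cc23)cc1` — > 100000 nM
compound 2 `COc1ccc2nc(C)cc(OCC(=O)Nc3cc(OC)c(Cl)cc3OC)c2c1` — > 100000 nM

In a toxicity assay on HepG2 cells (Homo sapiens) for inhibition, read by CellTiter-Glo, with a stated time of 48 h (a higher number here means a weaker inhibitor, a lower number a stronger inhibitor), compound 1 gives only a limit, > 100000 nM, and no number. Compound 2 likewise sits at a limit, > 100000 nM. Both values therefore rest at the top of the window, as noted in the limit of > 100000 nM in this assay, at which 2 of the 2 values shown sit, and compound 1 cannot be placed relative to compound 2 beyond saying that neither shows measurable inhibition of the cells.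

Compound 3 `COc1ccc2nc(C)cc(OCC(=O)Nc3cc(C)nc(C)n3)c2c1` is the next member to go into this assay. It differs from compound 1 by 2,6-dimethylpyrimidin-4-yl in place of 4-methoxyphenyl on an amide-type nitrogen, the new group sitting on the amide-type nitrogen whose other neighbour is the carbonyl carbon.

Among the measured compounds shown here, no measured step exists for this kind of change, and both values shown are limits, so no direction can be read from the series. The expected step of a number no higher from compound 1 to compound 3 (the limit leaves the size open) is none beyond the scatter, with compound 3 expected to remain at the limit. The estimate for compound 3 is 100000 nM, within 30000 nM to 300000 nM.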

Compound 3, half-maximal inhibitory concentration: > 100000 nM
Compound 3: only a limit was reported (the forecaster's own chance of this, stated with the estimate: 75%); the middle value lies on the limit itself.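

Compound 3 gives > 100000 nM in this assay, a limit and not a number. Compound 1 also stands at a limit, so no step can be read from compound 1 to compound 3: the limit of > 100000 nM in this assay, at which 3 of the 3 values shown sit. The compounds shown leave open whether 2,6-dimethylpyrimidin-4-yl in place of 4-methoxyphenyl changes the read-out at all.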